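The compounds below may be only part of what the source reports. "The series", "measured", "known", "first", "only" and "open" are said of these compounds alone.

Working notes on the diaryl urea series. Compound 1 `CCc1ccc(Nc2cc(NC(=O)Nc3cc(OC)cc(OC)c3)ncn2)cc1` and compound 2 `CCc1cccc(Nc2cc(NC(=O)Nc3cc(OC)cc(OC)c3)ncn2)c1` differ only in the position of the ethyl group on the phenyl ring carried by the amine nitrogen. In a functional assay on NCI-H520 cells (Homo sapiens) for inhibition, read by MTT assay, with a stated time of 48 h, tested at 10 uM (a higher number here means more inhibition at the concentration tested (going by the name of the read-out), a lower number less inhibition), compound 1 gives 23.5%, and compound 2 gives 23%. Among the measured compounds shown here, the single measured step, a number 0.5 percentage points lower from compound 1 to compound 2 (within the scatter), shows that moving the ethyl group leaves the read-out essentially unchanged; the two numbers lie within the usual scatter of each other, so no order between compound 1 and compound 2 can be claimed.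

Compound 3 `COc1cc(NC(=O)Nc2cc(Nc3cc(I)ccc3OC)ncn2)cc(OC)c1` keeps the whole of the remaining framework and alters only the aryl group on that amine nitrogen: 5-iodo-2-methoxyphenyl in place of 3-ethylphenyl on a nitrogen on an aromatic ring. For the measured compounds named here, the one measured step concerns a shift of an ethyl group around the ring and does not speak to an exchange of the ring substituents themselves, so no direct precedent exists. In the absence of a relevant step, the working assumption is that the read-out stays near the level of compound 2. For compound 3 the expected step is a number 2 percentage points higher from compound 2 to compound 3 (within the scatter). Compound 3 is therefore estimated at 25%, with a range from 5% to 50%.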

Compound 3, a percentage reported as inhibition, at one concentration (the size of the read-out at that concentration, not a potency): 55%
For compound 3 the middle estimate is 30 percentage points below the measured one, and the stated range ends below it.
By their numbers in this assay, from the lowest: compounds 2 and 1 (each within the scatter of the next); then compound 3.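

The aryl group on the nitrogen on an aromatic ring is clearly a position that can move the read-out in this assay: the exchange for 5-iodo-2-methoxyphenyl gives a number 32 percentage points higher from compound 2 to compound 3 (beyond the scatter) and, against the other ethyl isomer, a number 31.5 percentage points higher from compound 1 to compound 3 (beyond the scatter) as well. Moving the ethyl group had shown no such sensitivity (a number 0.5 percentage points lower from compound 1 to compound 2 (within the scatter)), so this position responds to a change of the aryl group and its substituents, although not to a shift of ethyl around the ring, and the rise appears from either ethylphenyl compound. Nothing available accounts for the size of this step, and the data give no reason for it.

The exchange brings in the iodine and the methoxy group together and removes the ethyl group in the same step, so the compounds shown do not tell whether either new substituent alone, as in a methoxyphenyl or an iodophenyl, would carry the rise. Also open, from the compounds shown here alone, is whether a bromine, a longer alkoxy chain or an amine on this ring would hold, extend or lose the gain seen with compound 3.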